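The source may report more compounds than this note shows. Statements on the series, on what has been measured and on what is new or still open speak of the compounds shown alone.

Compound 2, with the structure `Cc1ccccc1Nc1nc(SCc2ccc(C(F)(F)F)cc2)nc2ccccc12`, was tested in a functional assay on PC-3 cells (Homo sapiens) for cytotoxicity, read by MTT assay, with a stated time of 72 h (a higher number here means a weaker inhibitor, a lower number a stronger inhibitor), where compound 2 gives 36900 nM. Going by the values given here, only one other compound gives a point of comparison: compound 1, with the structure `CCCCCCNc1nc(SCc2ccc(C(F)(F)F)cc2)nc2ccccc12`, which in this assay gives 19000 nM. Of these two numbers compound 2 is the higher, but the step from compound 1 to compound 2 in this assay was a 1.9-fold higher number from compound 1 to compound 2 (0.29 log units; within the scatter), so the two compounds cannot be told apart. Compound 3, with the structure `FC(F)(F)c1ccc(CSc2nc(Nc3cccc(C(F)(F)F)c3)c3ccccc3n2)cc1`, carries the change (3-(trifluoromethyl)phenyl in place of 2-methylphenyl on a nitrogen on an aromatic ring). Among the compounds with values here, the only measured step, the one from compound 1 to compound 2, swapped a hexyl for a 2-methylphenyl at the same nitrogen and stayed within the scatter; it gives no indication that what sits on this nitrogen moves the number much, and no measured pair shows a trifluoromethyl being placed on that phenyl. Compound 3 is therefore expected to stay close to compound 2, with a step of a 1.0-fold higher number from compound 2 to compound 3 (0.00 log units; within the scatter) that lies within the scatter. In this assay compound 3 is estimated at 37000 nM, with a range from 12000 nM to 110000 nM.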

Compound 3, half-maximal inhibitory concentration: 12900 nM
For compound 3 the middle estimate is 2.9-fold (0.46 log units) above the measured one, and the stated range covers the measured number.
By their numbers in this assay, from the lowest: compounds 3, 1 and 2 (each within the scatter of the next, the first and the last beyond it).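

In this assay, going by these compounds alone, the exchange of 2-methylphenyl for 3-(trifluoromethyl)phenyl on the nitrogen gave a 2.9-fold lower number from compound 2 to compound 3 (0.46 log units; beyond the scatter) and is the first step at this position to pass beyond the scatter, so the group on this nitrogen can move the number, though only modestly here. The hexyl compound stays out of reach of this separation, with a 1.5-fold lower number from compound 1 to compound 3 (0.17 log units; within the scatter) as the step, so among the three compounds only the two aryl groups can be told apart, while compound 1 cannot be told apart from either compound 2 or compound 3. Nothing available bears on why the exchange of these two aryl groups changes the number.

Compound 2 and compound 3 differ both in the substituent on the phenyl and in where it sits, so the step cannot be assigned to the trifluoromethyl or to its place on the ring. Going by these compounds, what a 3-methylphenyl or a 2-(trifluoromethyl)phenyl on this nitrogen would give remains open, and so does the outcome for a 3-chlorophenyl or a shorter alkyl chain in the same place.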